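Swapping a Ring for a Chain on the Amide Nitrogen

The compounds below may be only part of what the source reports. "The series", "measured", "known", "first", "only" and "open" are said of these compounds alone.

Compound 3 `C=CC1=C(C(=O)NC2CCCCC2)C(c2ccc(OC)cc2)OC1` carries a cyclohexylamino group on the carbonyl carbon of the shared core. In a functional assay on HeLa cells (Homo sapiens) for cytotoxicity, read by MTT assay, with a stated time of 24 h (on this read-out higher numbers stand for weaker inhibition and lower numbers for stronger inhibition), compound 3 gives 24800 nM. Compound 1 `C=CC1=C(C(=O)O)C(c2ccc(OC)cc2)OC1`, with a hydroxy group on that carbonyl carbon, gives 44300 nM in this assay, and the step of a 1.8-fold lower number from compound 1 to compound 3 (0.25 log units; within the scatter) is within the scatter, so the two cannot be ranked. Compound 2 `C=CC1=C(C(=O)Nc2ccc(OCC)cc2)C(c2ccc(OC)cc2)OC1` reaches only a limit in this assay, reported as > 100000 nM. That limit is the limit of > 100000 nM in this assay, at which 1 of the 3 values shown sits. For the measured compounds named here, the step of an at least 4.0-fold lower number from compound 2 to compound 3 (0.60 log units; beyond the scatter) is the one change here that is beyond the scatter. Of the two plain numbers shown, compound 3 has the lower one, though it sits within the scatter of compound 1.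

Compound 4 `C=CC1=C(C(=O)NCCCCC)C(c2ccc(OC)cc2)OC1` differs from compound 3 by pentyl in place of cyclohexyl on an amide-type nitrogen. Going by the values given here, no measured step compares two saturated groups on that amide-type nitrogen; the step of an at least 4.0-fold lower number from compound 2 to compound 3 (0.60 log units; beyond the scatter) sets an aromatic group against a saturated ring, not a ring against a chain. An expected step of a 1.2-fold higher number from compound 3 to compound 4 (0.08 log units; within the scatter) is therefore not beyond the scatter. Compound 4 is expected to give 30000 nM, with a range from 12000 nM to 80000 nM.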

Compound 4, half-maximal inhibitory concentration: > 100000 nM
Compound 4 ended at the assay's limit (the forecaster's own chance of this, stated with the estimate: 10%); at least 3.3-fold (0.52 log units) between middle value and limit.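

In this assay, the choice of group on this amide-type nitrogen matters even between two saturated groups: the step of an at least 4.0-fold higher number from compound 3 to compound 4 (0.60 log units; beyond the scatter) shows that pentyl, a chain with no ring, cannot simply stand in for cyclohexyl. The carbonyl carbon also behaves differently here, as cyclohexylamino could not be ranked against hydroxy, while pentylamino gives the step of an at least 2.2-fold higher number from compound 1 to compound 4 (0.35 log units; beyond the scatter). Compound 2 and compound 4 cannot be read against each other, as each gives only a limit of the assay, not a number: the limit of > 100000 nM in this assay, at which 2 of the 4 values shown sit.

For the compounds shown here, whether the ring itself is what separates compound 3 from compound 4 stays open, with only one saturated ring and one chain to compare on this nitrogen. Cyclopentyl or a shorter chain such as butyl at the same place would bear on that question.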